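A Dimethoxyphenyl Sulfonamide Variant of Compound 3

This account rests on a few compounds, and the source may have more. Where it says the series, first, only, none or still open, it means among the compounds named here.

Of the compounds shown here, three sharing one core have been tested in a functional assay on SMMC-7721 cells (Homo sapiens) for antiproliferative activity, read by MTT assay, with a stated time of 72 h; on this read-out higher numbers stand for weaker inhibition and lower numbers for stronger inhibition. Compound 1 `CN(C(=O)c1ccco1)c1ccc2[nH]c(-c3n[nH]c4ccccc34)cc2n1` gives 28200 nM. Compound 2 `Cc1ccc(S(=O)(=O)N(C)c2ccc3[nH]c(-c4n[nH]c5ccccc45)cc3n2)cc1` gives 16300 nM, and compound 3 `CN(c1ccc2[nH]c(-c3n[nH]c4ccccc34)cc2n1)S(=O)(=O)c1ccc(Br)cc1` gives 11500 nM, the lowest of the three numbers, though its gap to compound 2 lies within the scatter. Compound 4 `COc1ccc(OC)c(S(=O)(=O)N(C)c2ccc3[nH]c(-c4n[nH]c5ccccc45)cc3n2)c1` carries 2,5-dimethoxyphenyl in place of 4-bromophenyl on a sulfonyl sulfur. The step that bears most on this change is a 1.4-fold lower number from compound 2 to compound 3 (0.15 log units; within the scatter), which exchanged one group on the same phenyl ring for another and stayed within the scatter; the steps of a 2.5-fold lower number from compound 1 to compound 3 (0.39 log units; beyond the scatter) and a 1.7-fold lower number from compound 1 to compound 2 (0.24 log units; within the scatter) concern the exchange of the furan-2-yl carbonyl for a sulfonyl and say less about ring substituents. Little change is therefore expected, a 1.1-fold higher number from compound 3 to compound 4 (0.05 log units; within the scatter). Compound 4 is estimated at 13000 nM, within a range from 6000 nM to 30000 nM.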

Compound 4, half-maximal inhibitory concentration: 4280 nM
Estimate against measurement, compound 4: 3.0-fold (0.48 log units) above; measured number below the stated range.
By their numbers in this assay, from the lowest: compound 4; then compounds 3, 2 and 1 (each within the scatter of the next, the first and the last beyond it).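

At this place on the sulfonyl sulfur, the choice of aryl group can shift the number beyond the scatter in this assay: the 2,5-dimethoxyphenyl group gives a 2.7-fold lower number from compound 3 to compound 4 (0.43 log units; beyond the scatter) and a 3.8-fold lower number from compound 2 to compound 4 (0.58 log units; beyond the scatter). Among the compounds shown here, the earlier exchange of bromo for methyl on the phenyl ring stayed within the scatter, so compound 4 is the first sulfonamide here to stand clearly apart from another. Nothing available explains this difference.

From the compounds shown here alone, it remains open whether a single methoxy group would suffice, and how a phenyl ring carrying an amine or a carboxylic acid would compare.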